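The compounds below may be only part of what the source reports. "The series", "measured", "known", "first", "only" and "open" are said of these compounds alone.

Compound 1 `CC(=O)c1cc(C)c(OCCCCC#N)cc1O` carries a methyl on a saturated chain carbon bound to an aromatic carbon. In an assay on isolated protein for binding affinity to leukotriene B4 receptor 1 (Homo sapiens), tested at 1 uM (on this read-out lower numbers stand for less inhibition and higher numbers for more inhibition at the one concentration tested (going by the name of the read-out)), compound 1 gives 35%. Compound 2 `CCc1cc(C(C)=O)c(O)cc1OCCCCC#N` differs from it by methyl in place of hydrogen on a saturated chain carbon bound to an aromatic carbon, and that change made a step of a number 22 percentage points higher from compound 1 to compound 2 (beyond the scatter). Compound 3 `CCCCc1cc(C(C)=O)c(O)cc1OCCCCC#N` differs from compound 1 by propyl in place of hydrogen on a saturated chain carbon bound to an aromatic carbon; in this assay compound 3 gives 13%, while compound 2 gives 57%, so the step of a number 44 percentage points lower from compound 2 to compound 3 (beyond the scatter) is the largest seen among these three. Compound 4 `CCCCCc1cc(C(C)=O)c(O)cc1OCCCCC#N` has not yet been measured. It differs from compound 3 by methyl in place of hydrogen on a saturated chain carbon, four bonds along the chain from an aromatic carbon. Going by the values given here, this is the same kind of change as the one from compound 1 to compound 2, but the place is not the same: there the entering methyl sits on a saturated chain carbon bound to an aromatic carbon, here it sits four bonds along the chain from an aromatic carbon. The earlier step rose, yet lengthening the chain further cost heavily in the step from compound 2 to compound 3, so for compound 4 a step of about a number 2 percentage points higher from compound 3 to compound 4 (within the scatter) is expected, with the chain now longer than in any measured compound. Compound 4 is estimated to give about 15% in this assay, between 0% and 40%.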

Compound 4, a percentage reported as inhibition, at one concentration (the size of the read-out at that concentration, not a potency): 14%
Estimate against measurement, compound 4: 1 percentage points above; the range from low to high includes it.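

Adding one methyl does not carry over from one core to the next: on the longer chain it gives a number 1 percentage points higher from compound 3 to compound 4 (within the scatter), so it leaves no readable change in this assay, and it does not repeat the earlier gain: the same change on two cores in this assay, a number 22 percentage points higher (beyond the scatter) from compound 1 to compound 2 and a number 1 percentage points higher (within the scatter) from compound 3 to compound 4, 21 percentage points apart, beyond the scatter of two such steps. Putting propyl in place of hydrogen lowers the number on both cores, and the step of a number 43 percentage points lower from compound 2 to compound 4 (beyond the scatter) shows that the size of the drop does not transfer: the same change on two cores in this assay, a number 22 percentage points lower (beyond the scatter) from compound 1 to compound 3 and a number 43 percentage points lower (beyond the scatter) from compound 2 to compound 4, 21 percentage points apart, beyond the scatter of two such steps. Butyl in place of hydrogen likewise gives a number 21 percentage points lower from compound 1 to compound 4 (beyond the scatter), so within these four compounds compound 2 alone stands above the rest, but this shows neither why the numbers move nor how the compounds would rank in a measure of potency, since each number comes from one concentration.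

The compounds shown leave open how a propyl chain would read at this place on the shared core. They also leave open whether a cyclopropyl or a methoxy group there would match compound 2.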